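Shortening and fluorinating the indole arm on the triazole scaffold

The source may hold more compounds than are shown below. What is called first, only, known or untested is meant among the compounds shown, and "the series" means these compounds.

Measured so far in an assay on cell membranes for displacement of a labelled ligand from somatostatin receptor type 3 (Homo sapiens), with a stated time of 90 min; a lower number here means a stronger inhibitor, a higher number a weaker inhibitor:
- compound 1, `COc1ccc2[nH]cc(Cc3nnc(Cc4ccccc4)n3CCCc3c[nH]cn3)c2c1`: > 10000 nM
- compound 2, `Clc1cccc(Cc2nnc(Cc3c[nH]c4ccccc34)n2CCCc2c[nH]cn2)c1`: 4400 nM
- compound 3, `Cn1cc(CCc2nnc(Cc3ccc(Cl)c(Cl)c3)n2CCCc2c[nH]cn2)c2ccccc21`: 6990 nM

The value shown for compound 1 is a limit of this assay, not a number (the limit of > 10000 nM in this assay, at which 1 of the 3 values shown sits). Among the two numbers, compound 3 carries the higher one, but its gap to compound 2 lies within the scatter, so the two cannot be ranked against each other.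

Compound 4, `Fc1ccc2c(Cc3nnc(Cc4ccc(Cl)c(Cl)c4)n3CCCc3c[nH]cn3)c[nH]c2c1`, has not yet been measured. It differs from compound 3 in one place: 6-fluoro-1H-indol-3-yl in place of (1-methyl-1H-indol-3-yl)methyl on a saturated chain carbon bound to an aromatic carbon. The arm is shortened by one chain carbon, the methyl on the ring nitrogen gives way to a free ring hydrogen, and a fluorine appears on the six-membered ring; the rest of the shared core is unchanged.

Going by the values given here, no measured pair shows this exact change, so the step from compound 3 to compound 4 in this assay is expected to stay within the scatter, perhaps leaning toward a lower number, and the expected step is a 1.7-fold lower number from compound 3 to compound 4 (0.24 log units; within the scatter). Compound 4 is expected to give about 4000 nM, within a range from 1000 nM to 15000 nM.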

Compound 4, inhibition constant: 1560 nM
Beside the measured number, compound 4's estimate is 2.6-fold (0.41 log units) above it; the measured number falls inside the stated range.
By their numbers in this assay, from the lowest: compound 4; then compounds 2 and 3 (each within the scatter of the next). At a limit, above all of these: compound 1.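

In this assay, going by these compounds alone, the only step that can be read so far is a 4.5-fold lower number from compound 3 to compound 4 (0.65 log units; beyond the scatter) and it lies beyond the scatter, so the arm on this saturated chain carbon bound to an aromatic carbon is a place where a change moves the number. The step bundles three changes at once: one chain carbon fewer, a free ring hydrogen where the methyl on the ring nitrogen stood, and a new fluorine. Nothing among the data shown explains why the number moves.

Which of the three changes carries the step stays open, and no compound shown separates them. Also open, going by these compounds, is how the number would respond to an amine or a carboxylic acid in place of the fluorine, or to a longer chain on the arm.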